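This account rests on a few compounds, and the source may have more. Where it says the series, first, only, none or still open, it means among the compounds named here.

Compound 1 (`Cc1ccc2nc(-c3cccc4ccccc34)[nH]c(=O)c2c1`) gives > 50000 nM
Compound 2 (`Cc1ccc2nc(-c3cccc(C(F)(F)F)c3)[nH]c(=O)c2c1`) gives > 50000 nM

In a functional assay on T47D cells (Homo sapiens) for cytotoxicity, read by MTT assay, with a stated time of 2 days (a higher number here means a weaker inhibitor, a lower number a stronger inhibitor), compound 1 gives > 50000 nM as a limit of the assay, not a number. Compound 2 gives > 50000 nM as a limit too, so its standing is known only as that limit. Compound 3 (`Cc1ccc2nc(-c3cccc(OC(F)(F)F)c3)[nH]c(=O)c2c1`) has trifluoromethoxy in place of trifluoromethyl on an aromatic carbon, meta to a large group (trifluoromethoxy in place of trifluoromethyl on an aromatic carbon). For the measured compounds named here, no measured pair shows this change, and the only guide is the limit of > 50000 nM in this assay, at which 2 of the 2 values shown sit, for now. A step of a number no higher from compound 2 to compound 3 (the limit leaves the size open) in this assay is expected to stay within the usual scatter, with no direction foreseen. For compound 3 the estimated value is 50000 nM (expected range 25000 nM to 100000 nM).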

Compound 3, half-maximal inhibitory concentration: > 50000 nM
Compound 3 was reported as a limit (the forecaster's own chance of this, stated with the estimate: 85%); the middle value lies on the limit itself.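

For the compounds shown here, compound 2 and compound 3 are both reported as limits, not numbers, so no step between them can be read: the limit of > 50000 nM in this assay, at which 3 of the 3 values shown sit.
On these data alone, whether any compound of this kind gives a number rather than a limit in this assay stays open.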